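Swapping the ring on the lactam nitrogen of compound 2

The source may report more compounds than this note shows. Statements on the series, on what has been measured and on what is new or still open speak of the compounds shown alone.

Two compounds share a core in which a dichlorobenzyl amide is joined to a five-membered lactam whose nitrogen carries a small aromatic ring. Compound 1 `O=C(NCc1ccc(Cl)cc1Cl)[C@@H]1CCC(=O)N1c1cccs1` bears thiophen-2-yl there, and in an assay on HEK293 cells for displacement of a labelled ligand from P2X purinoceptor 7 (Homo sapiens), read by scintillation counting, with a stated time of 1 h (on this read-out lower numbers stand for stronger inhibition and higher numbers for weaker inhibition), compound 1 gives 147 nM. Compound 2 `O=C(NCc1ccc(Cl)cc1Cl)[C@@H]1CCC(=O)N1c1ccco1` carries furan-2-yl instead, and in this assay compound 2 gives 118 nM. The step of a 1.2-fold lower number from compound 1 to compound 2 (0.10 log units; within the scatter) shows that these two numbers sit within the usual scatter of each other, so compound 2 cannot be separated from compound 1 on the evidence so far.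

Compound 3 `O=C(NCc1ccc(Cl)cc1Cl)[C@@H]1CCC(=O)N1c1nccs1` differs from compound 2 by one change: 1,3-thiazol-2-yl in place of furan-2-yl on an amide-type nitrogen in a ring. Going by the values given here, the only measured step that speaks to a change of this five-membered ring is the one from compound 1 to compound 2, which stayed within the scatter. On that basis the number for compound 3 in this assay is expected to stay close to that of compound 2, with the estimated step of a 1.3-fold higher number from compound 2 to compound 3 (0.10 log units; within the scatter) meaning no change beyond the scatter. Compound 3 is therefore estimated at 150 nM, within a range of 60 nM to 400 nM.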

Compound 3, inhibition constant: 489 nM
Compound 3: middle estimate off by 3.3-fold (0.51 log units), on the low side; the measured number lies above the stated range.
By their numbers in this assay, from the lowest: compounds 2 and 1 (each within the scatter of the next); then compound 3.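

The ring on the amide-type nitrogen in a ring can't be exchanged freely, even among five-membered aromatic rings of the same size: in this assay, the thiazole swap gives a 4.1-fold higher number from compound 2 to compound 3 (0.62 log units; beyond the scatter) and a 3.3-fold higher number from compound 1 to compound 3 (0.52 log units; beyond the scatter) and so moves the number beyond the scatter, which the exchange of thiophen-2-yl for furan-2-yl did not do. Compared with furan-2-yl, 1,3-thiazol-2-yl has one five-membered aromatic ring with 2 hetero atoms rather than 1, and 2 hydrogen-bond acceptors rather than 1, yet this single example can't show that either count governs the rise in the number. No measurement shown here gives a reason for the rise.

As far as these compounds go, it remains open whether an oxazol-2-yl ring, which also has a ring nitrogen, would give a number like that of compound 3 or one closer to those of compound 1 and compound 2. From the compounds shown here alone, it is equally open how a six-membered ring such as phenyl or pyridin-2-yl, or a small non-aromatic group such as methyl, would fare on the same nitrogen.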